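From Nitrile to Chloro on the Benzyl Ether

A few compounds are considered here, and "the series" means these few. Any claim that something is new, unique, unknown or untested is made for them only; others in the source may bear on it.

In a functional assay on B16 cells (Mus musculus) for antiproliferative activity, read by MTT assay, with a stated time of 24 h (a higher number here means a weaker inhibitor, a lower number a stronger inhibitor), compound 1 `C#CCOc1ccc2c(=O)c(-c3cc(OC)c(OC)cc3OC)coc2c1` gives 4500 nM. Compound 2 `COc1cccc(C(=O)Oc2ccc3c(=O)c(-c4cc(OC)c(OC)cc4OC)coc3c2)c1` is reported only as a limit, > 10000 nM. Going by the values given here, compound 3 `COc1cc(OC)c(-c2coc3cc(OCc4ccccc4C#N)ccc3c2=O)cc1OC` gives 2140 nM, the lowest of the numbers so far. Putting 2-cyanophenyl in place of ethynyl gave a 2.1-fold lower number from compound 1 to compound 3 (0.32 log units; beyond the scatter), and putting 2-cyanobenzyl in place of (3-methoxyphenyl)carbonyl gave an at least 4.6-fold lower number from compound 2 to compound 3 (0.66 log units; beyond the scatter). Compound 4 `COc1cc(OC)c(-c2coc3cc(OCc4ccccc4Cl)ccc3c2=O)cc1OC` carries chloro in place of cyano on an aromatic carbon, ortho to a large group (chloro in place of cyano on an aromatic carbon). Among the compounds with values here, no measured step makes this exchange, and the nearest, a 2.1-fold lower number from compound 1 to compound 3 (0.32 log units; beyond the scatter), was modest and changed far more of the group. The expected change is therefore small, a 1.2-fold higher number from compound 3 to compound 4 (0.07 log units; within the scatter), not beyond the scatter. For compound 4 the estimated value is 2500 nM, with an expected range of 1000 nM to 6000 nM.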

Compound 4, half-maximal inhibitory concentration: 4180 nM
Compound 4: the middle estimate sits 1.7-fold (0.22 log units) below what was measured, and the stated range covers the measured number.
By their numbers in this assay, from the lowest: compounds 3, 4 and 1 (each within the scatter of the next, the first and the last beyond it). At a limit, above all of these: compound 2.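

Cyano and chloro on this aromatic carbon, ortho to a large group, stay within the scatter of each other, a 2.0-fold higher number from compound 3 to compound 4 (0.29 log units; within the scatter), and the 2-chlorobenzyl ether is likewise within the scatter of the propargyl ether, a 1.1-fold lower number from compound 1 to compound 4 (0.03 log units; within the scatter); only the 2-cyanobenzyl compound stands beyond the scatter of compound 1. The 2-chlorobenzyl group still separates from the (3-methoxyphenyl)carbonyl group, an at least 2.3-fold lower number from compound 2 to compound 4 (0.37 log units; beyond the scatter). Compound 2 is known only as a limit: the limit of > 10000 nM in this assay, at which 1 of the 4 values shown sits.

Going by these compounds, whether an amine or a carboxylic acid on this aromatic carbon would stand beyond the scatter of compound 3 stays open. So does the effect of a longer chain between the oxygen and the ring.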